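The source may report more compounds than this note shows. Statements on the series, on what has been measured and on what is new or still open speak of the compounds shown alone.

Measured compounds:
Compound 1 `CCOC(=O)C1=C(C)NC(C)=C(C(=O)OCC)C1c1c(-c2ccccc2F)nc2sccn12` gives 5150 nM.
Compound 2 `CCOC(=O)C1=C(C)NC(C)=C(C(=O)OCC)C1c1c(-c2cc([N+](=O)[O-])c(Cl)cc2Cl)nc2sc(CC)cn12` gives 33 nM.
Compound 3 `CCOC(=O)C1=C(C)NC(C)=C(C(=O)OCC)C1c1c(-c2cc(OC)ccc2OC)nc2sc(C)cn12` gives 250 nM.

All three share one core and differ in the aryl group attached to it and in the small group on the fused ring. In an ADME assay on Left cardiac atrium (Cavia porcellus) (on this read-out lower numbers stand for an effect already at smaller amounts and higher numbers for an effect only at larger amounts of compound), compound 1 stands at the highest of the three numbers. Compound 3 comes nearest, and its number is still lower by a gap beyond the usual scatter; compound 2 lies furthest away and has the lowest number of the set.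

Compound 4 `CCOC(=O)C1=C(C)NC(C)=C(C(=O)OCC)C1c1c(-c2ccc(Br)c([N+](=O)[O-])c2)nc2sccn12` has not yet been measured. It differs from compound 1 in one place: 4-bromo-3-nitrophenyl in place of 2-fluorophenyl on an aromatic carbon. For the measured compounds named here, no pair of measured compounds isolates this change, so the expectation rests on a looser comparison. Compound 2, with 33 nM, and compound 3, with 250 nM, both carry a more heavily substituted aryl group and both give lower numbers than compound 1, though each also carries a group on the fused ring that compound 4 lacks. On that basis the step from compound 1 to compound 4 is expected to be a 13-fold lower number from compound 1 to compound 4 (1.11 log units; beyond the scatter), toward a lower number and beyond the scatter. Compound 4 is expected to give about 400 nM in this assay, within a range of 80 nM to 2000 nM.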

Compound 4, half-maximal effective concentration: 1270 nM
Compound 4: middle estimate off by 3.2-fold (0.50 log units), on the low side, within the range that was stated.
By their numbers in this assay, from the lowest: compound 2; then compound 3; then compound 4; then compound 1.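

In this assay, placing 4-bromo-3-nitrophenyl instead of 2-fluorophenyl on the aromatic carbon of the five-membered ring gives a 4.1-fold lower number from compound 1 to compound 4 (0.61 log units; beyond the scatter). For the compounds shown here, this is the first comparison here in which only the aryl group changes while the rest of the molecule stays the same, so it shows that this change alone can move the read-out beyond the usual scatter, although the step is modest. The data shown offer no explanation for this step.

On these data alone, the change removes the fluorine and adds both a bromine and a nitro group, so it remains open how much of the step belongs to each group, and a 4-bromophenyl or a 3-nitrophenyl at this position would help to separate them. Going by these compounds alone, it is also open whether an amine or a carboxylic acid in place of the nitro group would keep the lower number, and how a methyl or ethyl on the fused ring would act when it is the only change from compound 1 or compound 4.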